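Swapping an Amide for a Nitrile on a Weak Inhibitor

This account rests on a few compounds, and the source may have more. Where it says the series, first, only, none or still open, it means among the compounds named here.

Three compounds sharing one core were tested in an assay on isolated protein for inhibition of 2-Hydroxyacid oxidase 2 (Homo sapiens), tested at 1 uM; a lower number here means a weaker effect, a higher number a stronger effect of the compound at the concentration tested. Compound 1 `Cc1n[nH]c(C(=O)O)c1Cc1cccc(-c2cccc(F)c2)c1` gives 20%, compound 2 `Cc1n[nH]c(C(=O)O)c1Cc1cccc(-c2ccc(C#N)cc2)c1` gives 13%, and compound 3 `Cc1n[nH]c(C(=O)O)c1Cc1cccc(C(N)=O)c1` gives 8%, the lowest of the three numbers, though its gap to compound 2 is within the scatter. The step of a number 12 percentage points lower from compound 1 to compound 3 (beyond the scatter) is the only one beyond the scatter; a number 7 percentage points lower from compound 1 to compound 2 (within the scatter) and a number 5 percentage points lower from compound 2 to compound 3 (within the scatter) are not, so all three sit at the weak end and differ little.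

Compound 4 `Cc1n[nH]c(C(=O)O)c1Cc1cccc(C#N)c1` has not been measured. It differs from compound 3 by cyano in place of carbamoyl on an aromatic carbon. For the measured compounds named here, no measured step trades these two groups directly. The nearest hint is compound 2, which carries cyano on its outer ring and gives 13%, close to compound 3. With every step among compounds 1, 2 and 3 modest or within the scatter, the expected step is a number 1 percentage points higher from compound 3 to compound 4 (within the scatter), not beyond the scatter. The estimate for compound 4 is 9%, with a range from 0% to 20%.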

Compound 4, a percentage reported as inhibition, at one concentration (the size of the read-out at that concentration, not a potency): 6%
For compound 4 the middle estimate is 3 percentage points above the measured one, and the stated range covers the measured number.
By their numbers in this assay, from the lowest: compounds 4, 3, 2 and 1 (each within the scatter of the next, the first and the last beyond it).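

For the compounds shown here, this is the first direct trade between the two groups: replacing the carbamoyl, which has a hydrogen-bond donor, with a cyano, which has none, gives a number 2 percentage points lower from compound 3 to compound 4 (within the scatter) in this assay and does not separate the two compounds. Removing the outer ring from the larger compounds gives two different results, with a number 7 percentage points lower from compound 2 to compound 4 (within the scatter) and a number 14 percentage points lower from compound 1 to compound 4 (beyond the scatter) showing that only the 3-fluorophenyl compound stands apart from compound 4, as it does from compound 3. Nothing measured here accounts for these numbers.

As far as these compounds go, it remains open whether any small group at this position could raise the read-out beyond the scatter, for example an amine or a hydroxyl. Also open, from the compounds shown here alone, is how an unsubstituted phenyl would compare with the 3-fluorophenyl and 4-cyanophenyl groups.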